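Replacing thiophen-2-yl by oxolan-2-yl in the series

A few compounds are considered here, and "the series" means these few. Any claim that something is new, unique, unknown or untested is made for them only; others in the source may bear on it.

- Compound 1 `Oc1ccc(CN(Cc2ccccc2)Cc2ccc(O)c3ncccc23)c2cccnc12` gives < 0.5 uM (a limit)
- Compound 2 `Oc1ccc(CN(Cc2cccc(I)c2)Cc2ccc(O)c3ncccc23)c2cccnc12` gives 2 uM (a number)
- Compound 3 `Oc1ccc(CN(Cc2cccs2)Cc2ccc(O)c3ncccc23)c2cccnc12` gives < 0.2 uM (a limit)

In a functional assay on U-87MG ATCC cells (Homo sapiens) for antiproliferative activity, with a stated time of 3 days (on this read-out higher numbers stand for an effect only at larger amounts of compound and lower numbers for an effect already at smaller amounts), the shared core stays fixed and only the group on a saturated chain carbon bound to an amine nitrogen varies. Compound 3 stands only at a limit (< 0.2 uM), not at a number.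

The next change puts oxolan-2-yl in place of thiophen-2-yl at that same place and gives compound 4 `Oc1ccc(CN(Cc2ccc(O)c3ncccc23)CC2CCCO2)c2cccnc12` (oxolan-2-yl in place of thiophen-2-yl on a saturated chain carbon bound to an amine nitrogen). Two measured steps show that the read-out responds to this group: an at least 10-fold lower number from compound 2 to compound 3 (1.00 log units; beyond the scatter) and an at least 4.0-fold higher number from compound 1 to compound 2 (0.60 log units; beyond the scatter) are both beyond the scatter. The third, a step that the two limits leave unreadable from compound 1 to compound 3, gives no usable size. For the measured compounds named here, no measured compound carries a non-aromatic ring at this place, so the size rests on weak ground.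

A modest move toward a higher number is expected, written as an at least 2.0-fold higher number from compound 3 to compound 4 (0.30 log units; that floor lies within the scatter) on the basis of that limit. The value for compound 4 is estimated at 0.4 uM (expected range 0.1 uM to 1.5 uM).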

Compound 4, concentration for half-maximal effect: 5 uM
Compound 4: middle estimate off by 13-fold (1.10 log units), on the low side; measured number outside the range, above it.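

In this assay, oxolan-2-yl is the only non-aromatic ring at this place on a saturated chain carbon bound to an amine nitrogen, and it gives a higher number than each aromatic group shown: an at least 25-fold higher number from compound 3 to compound 4 (1.39 log units; beyond the scatter), an at least 10-fold higher number from compound 1 to compound 4 (1.00 log units; beyond the scatter) and a 2.5-fold higher number from compound 2 to compound 4 (0.40 log units; beyond the scatter). Compound 3 carries a limit, not a number: the limit of < 0.2 uM in this assay, at which 1 of the 4 values shown sits. Compound 1 also carries a limit, not a number: the limit of < 0.5 uM in this assay, at which 1 of the 4 values shown sits.

With one compound of this kind, the step from thiophen-2-yl cannot be divided between the loss of the aromatic ring and the exchange of sulfur for oxygen; furan-2-yl would keep an aromatic ring with oxygen, and thiolan-2-yl a non-aromatic ring with sulfur. The compounds shown also leave open how cyclopentyl, with no hetero atom in a non-aromatic ring, or an open chain such as 2-methoxyethyl would compare with oxolan-2-yl at this place.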